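A few compounds are considered here, and "the series" means these few. Any claim that something is new, unique, unknown or untested is made for them only; others in the source may bear on it.

Measured compounds:
- compound 1, `COc1ccc(-c2cc(C(=O)Nc3nc4ccc(Cl)cc4s3)nc3cc(-c4ccccc4)nn23)cc1`: 4890 nM
- compound 2, `COc1ccc(-c2cc(C(=O)Nc3nc4ccc(F)cc4s3)nc3cc(-c4ccccc4)nn23)cc1`: 35500 nM

Going by the values given here, in a functional assay on MCF7 cells (Homo sapiens) for cytotoxicity, read by MTT assay, with a stated time of 48 h (a lower number here means a stronger inhibitor, a higher number a weaker inhibitor), compound 2 gives 35500 nM, the higher of the two numbers so far; its nearest neighbour, compound 1, gives 4890 nM. Among the compounds with values here, the single step between them, a 7.3-fold higher number from compound 1 to compound 2 (0.86 log units; beyond the scatter), is the only measured step bearing on the next compound.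

Compound 3, `COc1ccc(-c2cc(C(=O)Nc3nc4ccccc4s3)nc3cc(-c4ccccc4)nn23)cc1`, is not yet measured. It differs from compound 2 by hydrogen in place of fluoro on an aromatic carbon. Within the data shown here, no compound yet shows the unsubstituted position, so the direction rests on one step only: going from chloro to fluoro raised the number beyond the scatter, and removing the fluoro altogether is taken as a further move in the same direction, though a small one, possibly within the scatter. Compound 3 is therefore expected to give about 45000 nM, estimated range 15000 nM to 130000 nM, a step of a 1.3-fold higher number from compound 2 to compound 3 (0.10 log units; within the scatter).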

Compound 3, half-maximal inhibitory concentration: 2230 nM
Beside the measured number, compound 3's estimate is 20-fold (1.30 log units) above it, outside the stated range (below it).
By their numbers in this assay, from the lowest: compound 3; then compound 1; then compound 2.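

In this assay, hydrogen in place of fluoro gives a 16-fold lower number from compound 2 to compound 3 (1.20 log units; beyond the scatter), and hydrogen in place of chloro gives a 2.2-fold lower number from compound 1 to compound 3 (0.34 log units; beyond the scatter). The position therefore does not follow a single trend running from chloro through fluoro to hydrogen: among these three compounds, the unsubstituted 1,3-benzothiazol-2-yl gives the lowest number, and each halogen raises it, fluoro by much more than chloro. Nothing available explains why the two halogens differ so widely in their effect on this read-out.

Still open, going by these compounds, is whether any group at this position can take the number below that of compound 3, for example methoxy, an amine or a nitrile. On these data alone, it is also open where bromo would fall relative to chloro and fluoro.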